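A Repeated Exchange of Fluoronitrophenyl Groups

A few compounds are considered here, and "the series" means these few. Any claim that something is new, unique, unknown or untested is made for them only; others in the source may bear on it.

The measured compounds are:
Compound 1, `COC(=O)c1ccc(CN(CCCc2c(N)nc(N)nc2O)c2cc(F)c(F)cc2[N+](=O)[O-])cc1`, which in a functional assay on CCRF-CEM cells (Homo sapiens) for cytotoxicity, in the absence of a further agent (a lower number here means a stronger inhibitor, a higher number a weaker inhibitor), gives 59000 nM.
Compound 2, `COC(=O)c1ccc(CN(CCCc2c(N)nc(N)nc2O)c2ccc([N+](=O)[O-])c(F)c2F)cc1`, which in this assay gives 41000 nM.
Compound 3, `CC(C)(C)OC(=O)CCC(Nc1ccc(CN(CCCc2c(N)nc(N)nc2O)c2ccc([N+](=O)[O-])c(F)c2F)cc1)C(=O)OC(C)(C)C`, which in this assay gives 24000 nM.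

Compounds 1 and 2 differ in one place: 4,5-difluoro-2-nitrophenyl in place of 2,3-difluoro-4-nitrophenyl on an amine nitrogen. The step that this change made is a 1.4-fold higher number from compound 2 to compound 1 (0.16 log units; within the scatter), so the two values are not separated in this assay. Compound 3 carries a larger part that differs from compound 2; how the two cores differ is not broken down here, and their values in this assay lie within the scatter of each other.

Compound 4, `CC(C)(C)OC(=O)CCC(Nc1ccc(CN(CCCc2c(N)nc(N)nc2O)c2cc(F)c(F)cc2[N+](=O)[O-])cc1)C(=O)OC(C)(C)C`, is not yet measured. It arises from compound 3 by the same change seen between compounds 2 and 1: 4,5-difluoro-2-nitrophenyl in place of 2,3-difluoro-4-nitrophenyl on an amine nitrogen. The surroundings of the place are the same in both pairs. The step is therefore expected to resemble the earlier one, and the expected step is a 1.4-fold higher number from compound 3 to compound 4 (0.15 log units; within the scatter), resting on compound 2 and compound 1 with a 1.4-fold higher number from compound 2 to compound 1 (0.16 log units; within the scatter) and on the value of compound 3, 24000 nM. Compound 4 is thus estimated at 34000 nM in this assay, expected between 17000 nM and 70000 nM.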

Compound 4, half-maximal inhibitory concentration: 4800 nM
Beside the measured number, compound 4's estimate is 7.1-fold (0.85 log units) above it; measured number below the stated range.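

In this assay, placing 4,5-difluoro-2-nitrophenyl where 2,3-difluoro-4-nitrophenyl stood on the amine nitrogen gives a 5.0-fold lower number from compound 3 to compound 4 (0.70 log units; beyond the scatter), a step beyond the scatter, whereas the same change on the core of compound 2 left the two values unseparated. The change therefore did not carry over unaltered from one core to the other: the same change on two cores in this assay, a 1.4-fold higher number (0.16 log units; within the scatter) from compound 2 to compound 1 and a 5.0-fold lower number (0.70 log units; beyond the scatter) from compound 3 to compound 4, 7.2-fold (0.86 log units) apart, beyond the scatter of two such steps. This shows that, in these two pairs, the size and direction of the step depend on the core, but two pairs cannot show which part of the core is responsible or how the change would behave on any further core.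

The compounds shown leave open whether the difference between the two pairs would persist with free carboxylic acids in place of the tert-butyl esters. They also leave open whether it would hold with a longer chain on the amine nitrogen.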